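The source may report more compounds than this note shows. Statements on the series, on what has been measured and on what is new or still open speak of the compounds shown alone.

Working notes on the series. In a functional assay on SK-MEL-2 cells (Homo sapiens) for inhibition, read by sulforhodamine B assay, with a stated time of 48 h (on this read-out lower numbers stand for stronger inhibition of growth and higher numbers for weaker inhibition of growth), three compounds have been measured so far. Compound 1 `COc1cc(C)cc(-c2c(-c3ccnc(-c4ccc(C(C)=O)cc4)c3)cnn2CC#N)c1` gives 5880 nM, compound 2 `Cc1cc(O)cc(-c2nn(CC#N)cc2-c2ccnc(-c3ccc(Oc4ccccc4)cc3)c2)c1` gives 3440 nM, and compound 3 `COc1cc(C)cc(-c2nn(CC#N)cc2-c2ccnc(-c3ccc(N(C)C)cc3)c2)c1` gives 1010 nM. Compound 3 carries the lowest number of the three in this assay; the nearest of the others is compound 2, whose number stands beyond the scatter above it, and compound 1 lies further out again. No two of these compounds differ in only one place, so the three values cannot be read as single steps; they only mark the region within which the series has moved so far.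

Compound 4 `Cc1cc(O)cc(-c2nn(CC#N)cc2-c2ccnc(-c3ccc(N(C)C)cc3)c2)c1` has not yet been measured. It is related to compound 3 by hydrogen in place of methyl on an oxygen on an aromatic ring, a hydrogen in place of methyl on an oxygen on an aromatic ring; cut one bond further out the change reads methoxy to hydroxy, or 3-methoxy-5-methylphenyl to 3-hydroxy-5-methylphenyl. Compound 2 carries the hydroxy form, but its tail differs from that of compound 3, so nothing here isolates the oxygen change on its own. The step from compound 3 to compound 4 in this assay is therefore expected to be small, a 1.2-fold higher number from compound 3 to compound 4 (0.07 log units; within the scatter), with no direction claimed beyond the scatter. For compound 4 in this assay a value of 1200 nM is estimated, within 400 nM to 4000 nM.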

Compound 4, concentration for 50% growth inhibition: 4150 nM
For compound 4 the middle estimate is 3.5-fold (0.54 log units) below the measured one, outside the stated range (above it).
By their numbers in this assay, from the lowest: compound 3; then compounds 2, 4 and 1 (each within the scatter of the next).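

For the compounds shown here, with the dimethylamino tail held fixed, the methoxy to hydroxy change can now be read on its own in this assay: the step is a 4.1-fold higher number from compound 3 to compound 4 (0.61 log units; beyond the scatter) and lies beyond the scatter, so hydrogen in place of methyl on this oxygen weakens growth inhibition in this pair, which the earlier compounds could not show. With the hydroxy form held fixed, the second comparison gives a 1.2-fold higher number from compound 2 to compound 4 (0.08 log units; within the scatter) and no separation can be claimed, so dimethylamino in place of phenoxy on an aromatic carbon makes no readable difference in this hydroxy pair, and the advantage of the dimethylamino tail seen in compound 3 is not carried over to the hydroxy form. No data at hand bear on what lies behind the step at the oxygen.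

The compounds shown leave open whether the methoxy to hydroxy step has the same size with a tail other than dimethylamino, as the phenoxy tail appears here only with the hydroxy form. They also leave open how an ethoxy group on this oxygen, or an amine in place of the oxygen, would read in this assay.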